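This account rests on a few compounds, and the source may have more. Where it says the series, first, only, none or still open, it means among the compounds named here.

Compound 2 `O=C1/C(=C/c2ccccc2Br)NS(=O)(=O)c2ccccc21` gives 7430 nM in an assay for inhibition of Intestinal-type alkaline phosphatase (Homo sapiens), read by spectrophotometry, with stated times of 10 min and 20 min (a higher number here means a weaker inhibitor, a lower number a stronger inhibitor), the highest of the two numbers in hand; the nearest is compound 1 `COc1ccccc1/C=C1\NS(=O)(=O)c2ccccc2C1=O`, which gives 1240 nM in this assay. Among the compounds with values here, the only measured step, a 6.0-fold higher number from compound 1 to compound 2 (0.78 log units; beyond the scatter), exchanges one substituent on the aromatic ring for another. Compound 3 `O=C1/C(=C/c2cccc(Cl)c2)NS(=O)(=O)c2ccccc21` differs from compound 2 by 3-chlorophenyl in place of 2-bromophenyl on a double-bonded chain carbon bound to a double-bonded ring carbon. Within the data shown here, this exchange of one substituted phenyl for another has no direct counterpart among the measured steps; the step from compound 1 to compound 2 bears on it only in showing that a change on this ring can move the number in this assay by a modest amount. Among the measured compounds shown here, with no closer precedent, the step is expected to stay within or near the scatter, in no settled direction, and the expected step is a 1.5-fold lower number from compound 2 to compound 3 (0.17 log units; within the scatter). On that basis compound 3 is expected to give 5000 nM in this assay, within an estimated range of 1500 nM to 16000 nM.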

Compound 3, half-maximal inhibitory concentration: 3770 nM
Estimate against measurement, compound 3: 1.3-fold (0.12 log units) above; the measured number falls inside the stated range.
By their numbers in this assay, from the lowest: compound 1; then compounds 3 and 2 (each within the scatter of the next).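

In this assay, exchanging 2-bromophenyl for 3-chlorophenyl on a double-bonded chain carbon bound to a double-bonded ring carbon gives a 2.0-fold lower number from compound 2 to compound 3 (0.29 log units; within the scatter), so this change of substituted phenyl, unlike the earlier exchange of methoxy for bromo, does not move the number beyond the scatter. The step alters both the halogen and its place on the phenyl ring, and it cannot separate the two changes. Nothing available accounts for this result.

As far as these compounds go, it remains open whether 3-bromophenyl or 2-chlorophenyl would read the same way and so separate the halogen from its place on the ring. Also open, from the compounds shown here alone, is how an amine or a carboxylic acid on this phenyl ring, in place of the halogen, would read in this assay.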